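The source may hold more compounds than are shown below. What is called first, only, known or untested is meant among the compounds shown, and "the series" means these compounds.

Compound 1 `O=C(Nc1ccc(-n2ncc3c(F)cccc32)cc1)Nc1ccc(Cl)c(C(F)(F)F)c1` and compound 2 `CNc1cccc2c1cnn2-c1ccc(NC(=O)Nc2ccc(Cl)c(C(F)(F)F)c2)cc1` have the same shared core and differ in only one place. In a functional assay on NCI-H460 cells (Homo sapiens) for cytotoxicity, read by MTT assay, with a stated time of 72 h (on this read-out lower numbers stand for stronger inhibition and higher numbers for weaker inhibition), compound 1 gives 3400 nM, and in this assay compound 2 gives 2600 nM. Compound 1 has the highest of the two numbers shown, yet the step of a 1.3-fold lower number from compound 1 to compound 2 (0.12 log units; within the scatter) is within the scatter, so the two measurements cannot be told apart. Compound 3 `O=C(Nc1ccc(-n2ncc3cccnc32)cc1)Nc1ccc(Cl)c(C(F)(F)F)c1` has not yet been measured; compared with compound 1 it carries a group of 9 heavy atoms (6 carbon, 3 nitrogen; one five-membered aromatic ring with 2 hetero atoms, one six-membered aromatic ring with 1 hetero atom) in place of a group of 10 heavy atoms (7 carbon, 2 nitrogen, 1 fluorine; one five-membered aromatic ring with 2 hetero atoms, one six-membered aromatic ring of carbon only), on an aromatic carbon, so the new group brings one six-membered aromatic ring with 1 hetero atom where compound 1 had one of carbon only, and the fluorine is gone. For the measured compounds named here, only one measured step touches this part of the molecule, a 1.3-fold lower number from compound 1 to compound 2 (0.12 log units; within the scatter), and it shows that reworking that group moved the number little. That step exchanged a substituent rather than a ring atom, so it guides only loosely. The expected step is therefore no change at the digits printed from compound 1 to compound 3 (within the scatter), nothing beyond the scatter. Compound 3 is estimated at 3400 nM, with a range from 1500 nM to 8000 nM.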

Compound 3, half-maximal inhibitory concentration: 16600 nM
Compound 3: middle estimate off by 4.9-fold (0.69 log units), on the low side; the whole stated range lies below it.
By their numbers in this assay, from the lowest: compounds 2 and 1 (each within the scatter of the next); then compound 3.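

In this assay, the exchange of the 4-fluoro-1H-indazol-1-yl group, on an aromatic carbon para to a large group, gives a 4.9-fold higher number from compound 1 to compound 3 (0.69 log units; beyond the scatter), a step beyond the scatter. For the compounds shown here, the only earlier step at this part of the molecule, a 1.3-fold lower number from compound 1 to compound 2 (0.12 log units; within the scatter), lies within the scatter, so this result is the first sign that the number does respond to a change here: exchanging a substituent left it in place, while the change that brings a hetero atom into the six-membered ring and removes the fluorine raises it. Nothing shown here bears on why the number rises.

The step joins two changes in one, the loss of the fluorine and the arrival of the ring hetero atom, and the compounds shown do not tell which of them carries the rise. A group with hydrogen in place of the fluorine on the carbon-only ring would isolate the first change, while a fluorine or a methylamino group added to the ring holding the hetero atom would show whether a substituent there brings the number back down.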